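This account rests on a few compounds, and the source may have more. Where it says the series, first, only, none or still open, it means among the compounds named here.

Compound 1, `Cn1nc(Cc2nnc(SCCCCCCCC(=O)Nc3ccc(Cl)cc3Cl)n2CCC=O)c2ccccc2c1=O`, is the starting point. In an assay on 32D cells for inhibition of interleukin-15 (Mus musculus), read by resazurin assay, with stated times of 30 min and 2.5 days, in the presence of a further agent that is not named here (a higher number here means a weaker inhibitor, a lower number a stronger inhibitor), compound 1 gives 5500 nM. Compound 2, `Cn1nc(Cc2nnc(SCCCCCCCC(=O)Nc3ccc(Cl)cc3Cl)n2CCC(=O)O)c2ccccc2c1=O`, differs from compound 1 by hydroxy in place of hydrogen on a carbonyl carbon. Compound 2 gives only a limit in this assay, > 30000 nM, so its true value is not known as a number. That result is the limit of > 30000 nM in this assay, at which 1 of the 3 values shown sits. The change therefore produced an at least 5.4-fold higher number from compound 1 to compound 2 (0.73 log units; beyond the scatter).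

Compound 3, `Cn1c(Cc2nn(CCC=O)c(=O)c3ccccc23)nnc1SCCCCCCCC(=O)Nc1ccc(Cl)cc1Cl`, has the same atoms as compound 1 joined differently; the difference between the two cores is not broken down here. In this assay compound 3 gives 11700 nM, which stands as the higher of the two numbers measured.

Compound 4, `Cn1c(Cc2nn(CCC(=O)O)c(=O)c3ccccc23)nnc1SCCCCCCCC(=O)Nc1ccc(Cl)cc1Cl`, has not yet been measured. It differs from compound 3 by hydroxy in place of hydrogen on a carbonyl carbon, and the surroundings of the change are described in the same words as for compound 1 and compound 2, so this is the same change made on a different core. On that basis compound 4 is expected to show a 5.1-fold higher number from compound 3 to compound 4 (0.71 log units; beyond the scatter), resting on the earlier step of an at least 5.4-fold higher number from compound 1 to compound 2 (0.73 log units; beyond the scatter). The expected value for compound 4 in this assay is 60000 nM, likely between 25000 nM and 150000 nM.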

Compound 4, half-maximal inhibitory concentration: > 30000 nM
Compound 4 gave a limit, no number (the forecaster's own chance of this, stated with the estimate: 70%); the middle value lies beyond the limit too.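

In this assay compound 4 gives > 30000 nM, which is a limit of the assay and not a number. Replacing formyl with carboxy on the core of compound 3 produced an at least 2.5-fold higher number from compound 3 to compound 4 (0.40 log units; beyond the scatter), so this change weakened inhibition on both cores, and its direction carried over from one core to the other: the same change on two cores in this assay, an at least 5.4-fold higher number (0.73 log units; beyond the scatter) from compound 1 to compound 2 and an at least 2.5-fold higher number (0.40 log units; beyond the scatter) from compound 3 to compound 4; the limit leaves it open whether they differ. What this does not show is whether the size of the effect also carried over, as neither carboxy compound has an exact value: the limit of > 30000 nM in this assay, at which 2 of the 4 values shown sit.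

The compounds shown leave open how other groups in place of the formyl or carboxy group, such as an amine, an alcohol or a methyl ester, would read on either core. They also leave open whether a longer chain in place of 2-carboxyethyl would change the result, and what true values lie behind the two limits.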